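Chloro for Cyano on Two Different Rings

A few compounds are considered here, and "the series" means these few. Any claim that something is new, unique, unknown or untested is made for them only; others in the source may bear on it.

Three sulfonamides have been measured in a functional assay on KB cells (nasopharynx, Homo sapiens) for antiproliferative activity (a higher number here means a weaker inhibitor, a lower number a stronger inhibitor), and a fourth awaits measurement. Compound 1 `O=S(=O)(Nc1cccc2cc[nH]c12)c1ccc(Cl)cc1` gives 6 ug/mL in this assay. Compound 2 `N#Cc1ccc(S(=O)(=O)Nc2cccc3cc[nH]c23)cc1` gives 8.5 ug/mL in this assay. Compound 3 `COc1ccc(S(=O)(=O)Nc2cccc3c(C#N)c[nH]c23)cc1` gives 1.4 ug/mL in this assay, the lowest of the three numbers; its nearest neighbour is compound 1, and compound 2 is furthest from it. The difference between the core of compound 3 and the core of compound 2 is not broken down here.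

Compound 2 and compound 1 differ in one place: chloro in place of cyano on an aromatic carbon. That change made a step of a 1.4-fold lower number from compound 2 to compound 1 (0.15 log units; within the scatter).

Compound 4 `COc1ccc(S(=O)(=O)Nc2cccc3c(Cl)c[nH]c23)cc1` is not yet measured. It differs from compound 3 by the same kind of change: chloro in place of cyano on an aromatic carbon. The place is not the same: in compound 1 the chloro sits on an aromatic carbon of a six-membered aromatic ring of carbon only, para to a large group, whereas in compound 4 it sits on an aromatic carbon of a five-membered aromatic ring with 1 nitrogen, part of a fused or bridged system of two rings, two ring bonds from the ring nitrogen. Among the measured compounds shown here, because the one earlier instance of this kind of change gave only a 1.4-fold lower number from compound 2 to compound 1 (0.15 log units; within the scatter), the step from compound 3 to compound 4 is expected to be small as well, about a 1.2-fold lower number from compound 3 to compound 4 (0.07 log units; within the scatter). That expectation rests on a single example at a different place, so it is held loosely. Compound 4 is therefore estimated at 1.2 ug/mL in this assay, with a likely range from 0.5 ug/mL to 3.5 ug/mL.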

Compound 4, half-maximal inhibitory concentration: 0.55 ug/mL
Estimate against measurement, compound 4: 2.2-fold (0.34 log units) above, and the stated range covers the measured number.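

Chloro in place of cyano on an aromatic carbon of the five-membered aromatic ring with 1 nitrogen produced a 2.5-fold lower number from compound 3 to compound 4 (0.41 log units; beyond the scatter) in this assay. Set beside the only other instance of this change, on an aromatic carbon of a six-membered ring of carbon only, the new step cannot be told apart from the earlier one: the same change on two cores in this assay, a 1.4-fold lower number (0.15 log units; within the scatter) from compound 2 to compound 1 and a 2.5-fold lower number (0.41 log units; beyond the scatter) from compound 3 to compound 4, 1.8-fold (0.25 log units) apart, within the scatter of two such steps. Among the compounds shown here, this shows that, across these two pairs, the size of the step carried from one core to the other to within the scatter, but it does not show a reliable gain from the change, as only the step on the newer core lies beyond the scatter, and with the place of the change differing along with the core, neither can be credited or ruled out as an influence on the size of the step.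

The compounds shown leave open whether the change would give a step of similar size at one and the same place on both cores, or on any further core. They also leave open how an amine, a carboxylic acid or a longer chain in place of the chloro on the five-membered ring would read in this assay.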